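Replacing the ester side chain on the urea nitrogen

The source may hold more compounds than are shown below. What is called first, only, known or untested is meant among the compounds shown, and "the series" means these compounds.

Measured compounds:
compound 1, `CC[C@H](C)[C@H](NC(=O)N1CCC2(CC1)CN(C)C2c1ccc(Cl)cc1)C(=O)OC`, gives in an assay on HEK293 cells for inhibition of Voltage-dependent T-type calcium channel subunit alpha-1H (Homo sapiens), read by patch clamp, using a membrane potential dye (a lower number here means a stronger inhibitor, a higher number a weaker inhibitor), for compound 1 410 nM.
compound 2, `CC[C@H](C)[C@H](NC(=O)N1CCC2(CC1)CN(C(C)C)C2c1ccc(F)cc1)C(=O)OC`, gives for compound 2 256 nM.
compound 3, `CC[C@H](C)[C@H](NC(=O)N1CCC2(CC1)C(=O)N(c1cccc(F)c1)C2c1ccc(Cl)cc1)C(=O)OC(C)C`, gives for compound 3 45 nM.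

Compound 3 shows the lowest number of the three; compound 2 and compound 1 both stand beyond the scatter above it, compound 1 furthest. Compound 4, `CC[C@H](NC(=O)N1CCC2(CC1)C(=O)N(c1cccc(F)c1)C2c1ccc(Cl)cc1)c1ccccc1`, has not been measured. It differs from compound 3 in one place: a group of 9 heavy atoms (9 carbon; one six-membered aromatic ring of carbon only) in place of a group of 11 heavy atoms (9 carbon, 2 oxygen; no ring), on an amide-type nitrogen. Among the compounds with values here, no measured pair in this set covers a change of this kind, so no step size is known from the data. The step from compound 3 to compound 4 is expected to be modest, more likely upward than downward, estimated as a 1.9-fold higher number from compound 3 to compound 4 (0.28 log units; within the scatter). Compound 4 is therefore expected at about 85 nM, with a range from 25 nM to 300 nM.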

Compound 4, half-maximal inhibitory concentration: 224 nM
For compound 4 the middle estimate is 2.6-fold (0.42 log units) below the measured one, and the stated range covers the measured number.
By their numbers in this assay, from the lowest: compound 3; then compounds 4, 2 and 1 (each within the scatter of the next).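

Within the data shown here, replacing the ester side chain with 1-phenylpropyl on the amide-type nitrogen gives a 5.0-fold higher number from compound 3 to compound 4 (0.70 log units; beyond the scatter) in this assay as the first measured step at this position. Among these compounds, the side chain at this place therefore affects the read-out, and the ester is not the only group compatible with a value in the nanomolar range. Nothing available explains the size of this step. Still open, going by these compounds, is which part of the ester side chain accounts for the step, and how a carboxylic acid or a benzyl group on this nitrogen would compare.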